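Working notes: 4-fluorophenyl in place of cyclohexyl

The compounds below may be only part of what the source reports. "The series", "measured", "known", "first", "only" and "open" are said of these compounds alone.

- compound 1 `C=CS(=O)(=O)NC/C=C/c1cc(OC)cc(O)c1C(=O)OCC1CCCCC1` gives 26.5%
- compound 2 `CCN(CC)C/C=C/C(=O)NC/C=C/c1cc(OCCc2ccc(F)cc2)cc(O)c1C(=O)OC(C)C` gives 25.7%

In a functional assay on THP-1 cells (Homo sapiens) for inhibition, read by luminescence, with a stated time of 72 h, tested at 5 uM (a higher number here means more inhibition of growth at the concentration tested, a lower number less inhibition of growth), compound 1 gives 26.5% and compound 2 gives 25.7% as its reading. Within the data shown here, these two numbers lie within the scatter of each other, so compound 1 stands level with the only other measured compound and the pair cannot be ranked.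

Compound 3 `C=CS(=O)(=O)NC/C=C/c1cc(OC)cc(O)c1C(=O)OCc1ccc(F)cc1` has not yet been measured. It keeps the core of compound 1 and carries one change 4-fluorophenyl in place of cyclohexyl on a saturated chain carbon bound to an oxygen next to a carbonyl group in which 4-fluorophenyl takes the place of cyclohexyl on a saturated chain carbon bound to an oxygen next to a carbonyl group. Cut one bond further out, this reads cyclohexylmethyl to 4-fluorobenzyl.

Among the measured compounds shown here, no measured pair shows a step for this change, so the expectation rests only on compound 1 with its 26.5% reading. No shift beyond the scatter is expected in this assay and no firm direction can be given. The estimated move is a number 1.5 percentage points lower from compound 1 to compound 3 (within the scatter) and it is expected to stay within the scatter. For compound 3 the estimated value is 25% with an expected range from 12% to 40% in this measurement.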

Compound 3, percent growth inhibition at one concentration: 41.7%
Estimate against measurement, compound 3: 16.7 percentage points below; measured number above the stated range.
By their numbers in this assay, from the lowest: compounds 2 and 1 (each within the scatter of the next); then compound 3.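

In this assay, the swap of 4-fluorophenyl for cyclohexyl on a saturated chain carbon bound to an oxygen next to a carbonyl group gives a number 15.2 percentage points higher from compound 1 to compound 3 (beyond the scatter). Among these compounds, this is the first step that can be read from a single change, and it shows that the reading responds to the group at this position while the rest of compound 1 stays in place. No measurement bears on why cyclohexylmethyl and 4-fluorobenzyl differ in this way.

The step changes two things at once, a non-aromatic ring for an aromatic ring and the addition of fluorine, so the compounds shown do not say which of the two goes with the higher reading; an unsubstituted benzyl group at the same position would separate them. Also open, as far as these compounds go, is whether the reading keeps responding when the ring stands further from the oxygen, as in a 2-phenylethyl group, and whether the step holds with a different group on the rest of the shared core.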